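Triazole substituent swap in bis(benzyloxy)butenolide series

The compounds below may be only part of what the source reports. "The series", "measured", "known", "first", "only" and "open" are said of these compounds alone.

Measured compounds:
compound 1 `CC(C)(C)c1cn(C[C@H](O)[C@H]2OC(=O)C(OCc3ccccc3)=C2OCc2ccccc2)nn1` 18300 nM
compound 2 `Cc1ccc(S(=O)(=O)NCc2cn(C[C@H](O)[C@H]3OC(=O)C(OCc4ccccc4)=C3OCc3ccccc3)nn2)cc1` 14400 nM
compound 3 `O=C1O/C(=C\Cn2cc(-c3cc(F)cc(F)c3)nn2)C(OCc2ccccc2)=C1OCc1ccccc1` 17700 nM

In a functional assay on HeLa cells (Homo sapiens) for antiproliferative activity, read by MTT assay, with a stated time of 72 h (on this read-out lower numbers stand for stronger inhibition and higher numbers for weaker inhibition), compound 2 gives 14400 nM; compound 3 gives 17700 nM and compound 1 gives 18300 nM, and these three numbers lie within the scatter of one another, so no ordering is claimed.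

Compound 4 `O=C1O[C@H]([C@@H](O)Cn2cc(-c3cccc(O)c3)nn2)C(OCc2ccccc2)=C1OCc1ccccc1` is to be measured in this assay. It differs from compound 2 by 3-hydroxyphenyl in place of (((4-methylphenyl)sulfonyl)amino)methyl on an aromatic carbon.

Going by the values given here, the one measured step at this position, a 1.3-fold lower number from compound 1 to compound 2 (0.10 log units; within the scatter), left the number within the scatter. Compound 3, which also carries an aryl on the triazole, lies in the same band. No change beyond the scatter is therefore expected; the step of a 1.0-fold higher number from compound 2 to compound 4 (0.02 log units; within the scatter) is an estimate. Compound 4 is expected to give 15000 nM, with a range of 6000 nM to 40000 nM.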

Compound 4, half-maximal inhibitory concentration: 39300 nM
For compound 4 the middle estimate is 2.6-fold (0.42 log units) below the measured one; the measured number falls inside the stated range.
By their numbers in this assay, from the lowest: compounds 2, 3 and 1 (each within the scatter of the next); then compound 4.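

In this assay, going by these compounds alone, this carbon of the triazole proves sensitive to substitution: the steps of a 2.7-fold higher number from compound 2 to compound 4 (0.44 log units; beyond the scatter) and a 2.1-fold higher number from compound 1 to compound 4 (0.33 log units; beyond the scatter) are the first at this position to pass the scatter, both modest and both toward weaker inhibition. The exchange between tert-butyl and (((4-methylphenyl)sulfonyl)amino)methyl had shown no such shift. Nothing available bears on the cause of this loss.

From the compounds shown here alone, it remains open whether an unsubstituted phenyl or a 3-methoxyphenyl on the same core would sit with compound 4 or with compound 1 and compound 2, which would separate the contribution of the hydroxyl from that of the ring.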